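Replacing a Morpholinyl Hydrazide with a Pyridinyl Amide

The source may report more compounds than this note shows. Statements on the series, on what has been measured and on what is new or still open speak of the compounds shown alone.

The measured compounds in an ADME assay on MRC5 cells (Homo sapiens) for inhibition, with a stated time of 72 h (a higher number here means that more compound is needed for the effect, a lower number that less compound is needed), are these. Compound 1 `CCc1ccccc1C(=O)Nc1c[nH]nc1C(=O)N[C@H]1CC[C@H](OC)CC1` gives 3400 nM. Compound 2 `COc1cccc(OC)c1C(=O)Nc1c[nH]nc1C(=O)NN1CCOCC1` reaches only the assay limit, > 50000 nM. Compound 3 `CO[C@H]1CC[C@H](NC(=O)c2n[nH]cc2NC(=O)c2ccccc2)CC1` gives 800 nM.

Compound 2 therefore stands at the limit rather than at a number, and of the three values shown it is the only one there, as the evidence the limit of > 50000 nM in this assay, at which 1 of the 3 values shown sits, records. Compound 1 and compound 3 differ in one place, and the step of a 4.3-fold lower number from compound 1 to compound 3 (0.63 log units; beyond the scatter) is a modest change that lies beyond the scatter.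

Compound 4 `COc1cccc(OC)c1C(=O)Nc1c[nH]nc1C(=O)Nc1ccccn1` differs from compound 2 in one place: pyridin-2-yl in place of morpholin-4-yl on an amide-type nitrogen. The change is on an amide-type nitrogen whose other neighbour is the carbonyl carbon, so the morpholin-4-yl carbamoyl becomes a pyridin-2-yl carbamoyl. For the measured compounds named here, no measured step among the three compounds touches this position; the one measured step concerns an aromatic carbon elsewhere in the molecule. The expectation therefore rests only on the fact that compound 2 sits at the limit and that the two compounds with a number, compound 1 and compound 3, carry a different amide substituent. Compound 4 is expected to land at 20000 nM, within a range of 3000 nM to 60000 nM, with the step of an at least 2.5-fold lower number from compound 2 to compound 4 (0.39 log units; beyond the scatter) estimated, while a further limit remains a real possibility.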

Compound 4, half-maximal effective concentration: > 50000 nM
Compound 4: a limit, no number; the forecaster's own chance of this, stated with the estimate: 45%; middle value at least 2.5-fold (0.39 log units) away from the limit.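

In this assay compound 4 gives > 50000 nM, a limit of the assay and not a number. For the compounds shown here, compound 2 also stands at a limit, so no step from compound 2 to compound 4 can be read: the limit of > 50000 nM in this assay, at which 2 of the 4 values shown sit. The compounds shown leave open whether pyridin-2-yl in place of morpholin-4-yl on an amide-type nitrogen changes the value in this assay.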